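This account rests on a few compounds, and the source may have more. Where it says the series, first, only, none or still open, it means among the compounds named here.

In a functional assay on cells (Leukemia cell, Homo sapiens) for cytotoxicity, read by sulforhodamine B assay, with a stated time of 48 h (on this read-out lower numbers stand for stronger inhibition of growth and higher numbers for weaker inhibition of growth), compound 1 `COc1ccc2c(c1)/C(=C/c1c(-c3ccncc3)nc3sccn13)C(=O)N2C` gives 81800 nM and compound 2 `COc1nc2sc(C)cn2c1/C=C1/C(=O)Nc2ccc(O)cc21` gives 61700 nM, so these two values lie within the usual scatter of each other. Compound 3 `COc1nc2sc(C)cn2c1/C=C1/C(=O)Nc2ccccc21` is compound 2 with a single change, hydrogen in place of hydroxy on an aromatic carbon. Among the measured compounds shown here, no measured pair shows what this change does in this assay, so no step beyond the scatter is expected, in either direction. For compound 3 the estimated value is 60000 nM, with an expected range from 25000 nM to 120000 nM.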

Compound 3, concentration for total growth inhibition: 7250 nM
Estimate against measurement, compound 3: 8.3-fold (0.92 log units) above, and the stated range ends above it.
By their numbers in this assay, from the lowest: compound 3; then compounds 2 and 1 (each within the scatter of the next).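

In this assay hydrogen in place of hydroxy gives an 8.5-fold lower number from compound 2 to compound 3 (0.93 log units; beyond the scatter), a step beyond the usual scatter and the first measured sign that this aromatic carbon matters. The hydroxy is therefore not needed for growth inhibition in this pair, and the compound without it has the lower number. No evidence at hand explains this step. Going by these compounds, whether a methoxy, a fluorine or an amine on this carbon would stay close to compound 3 or move back toward compound 2 remains open.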